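From methyl ester to benzyl ester on a flat series

A few compounds are considered here, and "the series" means these few. Any claim that something is new, unique, unknown or untested is made for them only; others in the source may bear on it.

Of the compounds shown here, three sharing one core have been read so far in a functional assay on A549 cells (Homo sapiens) for cytotoxicity, read by colorimetric assay and MTT assay (a higher number here means a weaker inhibitor, a lower number a stronger inhibitor), as the test. Compound 1 (`COc1ccc(-c2cc3c(OC)cc(OC)cc3n(CC#N)c2=O)cc1`) gives 10000 nM in it, compound 2 (`COc1ccc(-c2cc3c(OC)cc(OC)cc3n(CCCC#N)c2=O)cc1`) gives 10000 nM in it, and compound 3 (`COC(=O)CCn1c(=O)c(-c2ccc(OC)cc2)cc2c(OC)cc(OC)cc21`) gives 10000 nM in it, so compound 3 stands level with both. Compound 4 (`COc1ccc(-c2cc3c(OC)cc(OC)cc3n(CCC(=O)OCc3ccccc3)c2=O)cc1`) differs from compound 3 in the ester alone (phenyl in place of hydrogen on a saturated chain carbon bound to an oxygen next to a carbonyl group): phenyl in place of hydrogen on a saturated chain carbon bound to an oxygen next to a carbonyl group, which reads as methoxycarbonyl to benzyloxycarbonyl. The measured steps all alter the chain on the aromatic nitrogen (no change at the digits printed from compound 1 to compound 2 (within the scatter); no change at the digits printed from compound 1 to compound 3 (within the scatter); no change at the digits printed from compound 2 to compound 3 (within the scatter)), and each stays within the scatter. None of them adds a phenyl, so they are only a loose guide, and a real gain cannot be ruled out. The expected outcome is no change at the digits printed from compound 3 to compound 4 (within the scatter) with no shift beyond the scatter. Compound 4 is estimated at 10000 nM with a range from 4000 nM to 20000 nM as the expected span.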

Compound 4, half-maximal inhibitory concentration: 10000 nM
Beside the measured number, compound 4's estimate shows no gap at the digits printed, within the range that was stated.
By their numbers in this assay, from the lowest: compounds 1, 2, 3 and 4 (each within the scatter of the next).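

The step from methoxycarbonyl to benzyloxycarbonyl shows no change at the digits printed from compound 3 to compound 4 (within the scatter) in this assay, so a phenyl on the saturated chain carbon bound to an oxygen next to a carbonyl group, with its 6 heavy atoms, leaves the reading as it was. Set against the two nitriles, the benzyl ester shows no change at the digits printed from compound 2 to compound 4 (within the scatter) and no change at the digits printed from compound 1 to compound 4 (within the scatter), so all four chains on the aromatic nitrogen read alike in this assay. Nothing available here accounts for this flat result.

All four values sit at one level. The compounds shown do not reveal whether any change to this chain can move the reading. Going by these compounds, whether a carboxylic acid or an amine at the end of the chain would do so remains open.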